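Moving the Nitrogen Around the Pyridine Ring

The source may report more compounds than this note shows. Statements on the series, on what has been measured and on what is new or still open speak of the compounds shown alone.

Compound 1 `Cc1sc2c(Nc3cccnc3)cccc2c1C` carries a pyridin-3-yl group on a nitrogen on an aromatic ring. Within the data shown here, in a functional assay for inhibition, with a stated time of 2 h, tested at 0.0312 g/L (a higher number here means more inhibition at the concentration tested (going by the name of the read-out), a lower number less inhibition), compound 1 gives 65.4%, the lower of the two numbers measured so far; compound 2 `COc1ccc(Nc2cccc3c(C)c(C)sc23)cc1` gives 96.8% in this assay, a gap beyond the usual scatter. Compound 3 `Cc1sc2c(Nc3ccccn3)cccc2c1C` is not yet measured and differs from compound 1 in one place: pyridin-2-yl in place of pyridin-3-yl on a nitrogen on an aromatic ring. Among the measured compounds shown here, no measured pair shows what this rearrangement does, so the expected change from compound 1 to compound 3 is small, a number 5.4 percentage points lower from compound 1 to compound 3 (within the scatter), not clearly beyond the scatter in either direction. Compound 3 is therefore estimated at 60%, within a range of 30% to 85% in this assay.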

Compound 3, a percentage reported as inhibition, at one concentration (the size of the read-out at that concentration, not a potency): 42.9%
Compound 3: middle estimate off by 17.1 percentage points, on the high side; the measured number falls inside the stated range.
By their numbers in this assay, from the lowest: compound 3; then compound 1; then compound 2.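

In this assay, among these compounds, where the ring nitrogen sits matters at this spot: with the same atoms joined differently, pyridin-2-yl in place of pyridin-3-yl gives a number 22.5 percentage points lower from compound 1 to compound 3 (beyond the scatter) and this is the first single-change pair. The group on a nitrogen on an aromatic ring is therefore sensitive to this rearrangement alone. Nothing available explains why the number moves this way. Still open, as far as these compounds go, is how pyridin-4-yl would compare with these two groups, and what an amine added to the pyridine ring would do.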